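The source may hold more compounds than are shown below. What is called first, only, known or untested is meant among the compounds shown, and "the series" means these compounds.

Measured compounds in a functional assay on ZR-75-1 cells (Homo sapiens) for cytotoxicity, read by MTT assay, with a stated time of 72 h; a lower number here means that less compound is needed, a higher number that more compound is needed for the effect:

compound 1, `CCc1cccc2c(OC)c(-c3occ(C)c3COC)ccc12`, gives 9.7 ug/mL
compound 2, `CCc1cccc2c(OC)c(-c3occ(C)c3COC(C)=O)ccc12`, gives 3.5 ug/mL
compound 3, `CCOc1c(-c2occ(C)c2COC)ccc2c(CC)cccc12`, gives only a limit of this assay, > 10 ug/mL

Compound 4, `CCOc1c(-c2occ(C)c2COC(C)=O)ccc2c(CC)cccc12`, is not yet measured in this assay.

Two changes run through the series. The first, (acetyl in place of methyl on an oxygen on a saturated carbon), is measured once: a 2.8-fold lower number from compound 1 to compound 2 (0.44 log units; beyond the scatter). The second, (methyl in place of hydrogen on a saturated chain carbon bound to an oxygen on an aromatic ring), separates the two cores: an at least 1.0-fold higher number from compound 1 to compound 3 (0.01 log units; that floor lies within the scatter). For compound 3 the reading is a limit of this assay, which is what the limit of > 10 ug/mL in this assay, at which 1 of the 3 values shown sits, records, so the true gap between compound 1 and compound 3 is not known beyond that floor.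

The change from compound 3 to compound 4 is acetyl in place of methyl on an oxygen on a saturated carbon. Its place line matches that of the change from compound 1 to compound 2 word for word, so it is the same change, made on the other core. Among the measured compounds shown here, the only measured instance of it is the step from compound 1 to compound 2, and the expectation for compound 4 rests on carrying that step size over to a starting point known only as a limit. A step of about an at least 1.4-fold lower number from compound 3 to compound 4 (0.15 log units; that floor lies within the scatter) is therefore expected from compound 3 to compound 4 in this assay. Compound 4 is estimated at 7 ug/mL in this assay, with a range from 3 ug/mL to 15 ug/mL, the width reflecting that compound 3 sits at a limit rather than a number.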

Compound 4, concentration for half-maximal effect: 4.9 ug/mL
For compound 4 the middle estimate is 1.4-fold (0.15 log units) above the measured one; measured number inside the range.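

In this assay, acetyl in place of methyl on the core of compound 3 gives an at least 2.0-fold lower number from compound 3 to compound 4 (0.30 log units; that floor lies within the scatter), which fits the step seen on the other core, but this floor alone does not establish a real lowering and leaves the size of the step on this core unknown: the same change on two cores in this assay, a 2.8-fold lower number (0.44 log units; beyond the scatter) from compound 1 to compound 2 and an at least 2.0-fold lower number (0.30 log units; that floor lies within the scatter) from compound 3 to compound 4; the limit leaves it open whether they differ. In this assay compound 3 gives > 10 ug/mL, which is a limit and not a number. The other change, methyl in place of hydrogen on a saturated chain carbon bound to an oxygen on an aromatic ring, comes to a 1.4-fold higher number from compound 2 to compound 4 (0.15 log units; within the scatter) among the acetoxymethyl members, so the two cores cannot be told apart with acetyl in place, and two pairs remain a thin basis for any general rule about carrying the change across cores: the same change on two cores in this assay, an at least 1.0-fold higher number (0.01 log units; that floor lies within the scatter) from compound 1 to compound 3 and a 1.4-fold higher number (0.15 log units; within the scatter) from compound 2 to compound 4; the limit leaves it open whether they differ.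

Acetyl and methyl are the only groups shown on an oxygen on a saturated carbon, so the free alcohol, a longer acyl chain such as butyryl, and a benzoyl group there remain open. From the compounds shown here alone, an amine in that place also remains open, as does whether the step holds in cell lines other than this one.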